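A few compounds are considered here, and "the series" means these few. Any claim that something is new, unique, unknown or untested is made for them only; others in the source may bear on it.

Working notes on the series.

Compound 1 `COc1cc2occ(-c3csc4ccccc34)c(=O)c2c(OC)c1OC` and compound 2 `COc1cc2occ(-c3csc4ccccc34)c(=O)c2cc1OC` share one core; compound 3 `COc1ccc(C(=O)/C=C/c2csc3ccccc23)c(O)c1` and the as yet unmeasured compound 4 `COc1cc(O)c(C(=O)/C=C/c2csc3ccccc23)cc1OC` share another. The difference between the two cores is not broken down here.

In a functional assay on MCF7 cells (Homo sapiens) for antiproliferative activity, read by sulforhodamine B assay, with a stated time of 72 h (a higher number here means a weaker inhibitor, a lower number a stronger inhibitor), compound 1 gives 740 nM. For compound 2 the same assay returns only a limit, > 10000 nM, which marks where the measurable range ends (the limit of > 10000 nM in this assay, at which 1 of the 3 values shown sits). The change from compound 2 to compound 1 is methoxy in place of hydrogen on an aromatic carbon, and it produced an at least 13-fold lower number from compound 2 to compound 1 (1.13 log units; beyond the scatter).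

Compound 3 gives 7500 nM in this assay, the highest actual number among the measured compounds, with compound 1 as its nearest neighbour.

Compound 4 is obtained from compound 3 by methoxy in place of hydrogen on an aromatic carbon. This is the same kind of change as that from compound 2 to compound 1, not the same change: in the measured pair the ring is part of a fused or bridged system of two rings and the entering group sits ortho to a fused ring and meta to a fused ring and a methoxy group, whereas in compound 4 the ring is not fused and the group sits meta to a large group and para to a hydroxy group.

Going by the values given here, on the single measured precedent, which started from a limit and on a different core, compound 4 is expected to give 1500 nM, a step of a 5.0-fold lower number from compound 3 to compound 4 (0.70 log units; beyond the scatter) from compound 3, with a range of 400 nM to 6000 nM reflecting that only one pair supports the direction.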

Compound 4, half-maximal inhibitory concentration: 710 nM
Compound 4: the middle estimate sits 2.1-fold (0.32 log units) above what was measured; the range from low to high includes it.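

The step on the core of compound 3 is an 11-fold lower number from compound 3 to compound 4 (1.02 log units; beyond the scatter) in this assay and runs in the same direction as the step on the core of compound 1, so methoxy in place of hydrogen on an aromatic carbon lowers the number on both cores shown. Set side by side, the two steps read: the same change on two cores in this assay, an at least 13-fold lower number (1.13 log units; beyond the scatter) from compound 2 to compound 1 and an 11-fold lower number (1.02 log units; beyond the scatter) from compound 3 to compound 4; the limit leaves it open whether they differ. The direction is therefore carried from one core to the other, but equal size is not shown, and this rests on one pair per core, with one of the two steps starting from a value that is only a limit of the assay, because of this entry: the limit of > 10000 nM in this assay, at which 1 of the 4 values shown sits.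

The compounds shown leave open whether the step belongs to methoxy itself or whether a longer chain such as ethoxy, or an amine, in the same place on the ring would give a similar one. They also leave open whether the change holds on any core beyond these two, and how much the step on the core of compound 3 depends on the hydroxy group para to the entering methoxy.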